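Trifluoromethyl on a Fused Core and Cell Tolerance

This account rests on a few compounds, and the source may have more. Where it says the series, first, only, none or still open, it means among the compounds named here.

Four related compounds are considered here. Compound 1 `O=[N+]([O-])C1=NNc2nc(C(F)(F)F)nn2C1c1ccc(O)cc1O` and compound 2 `O=[N+]([O-])C1=NNc2ncnn2C1c1ccc(O)cc1O` share one core, while compound 3 `O=[N+]([O-])C1=CNc2ncnn2C1c1ccc(O)cc1O` and compound 4 `O=[N+]([O-])C1=CNc2nc(C(F)(F)F)nn2C1c1ccc(O)cc1O` share another; the difference between the two cores is not broken down here. In an ADME assay on MDCK cells (Canis lupus familiaris) for cytotoxicity (a higher number here means that more compound is tolerated, a lower number that less compound is tolerated), compound 2 gives 90000 nM. In this assay compound 1 gives 108000 nM. The change from compound 2 to compound 1 is trifluoromethyl in place of hydrogen on an aromatic carbon and it gave a 1.2-fold higher number from compound 2 to compound 1 (0.08 log units; within the scatter). For compound 3 only a limit of the assay is known in this assay, namely > 1080000 nM, which is the limit of > 1080000 nM in this assay, at which 1 of the 3 values shown sits. Compound 4 has no value in this assay yet; it differs from compound 3 by trifluoromethyl in place of hydrogen on an aromatic carbon, the same change as that between compound 2 and compound 1, made at a place described in the same words. Because a 1.2-fold higher number from compound 2 to compound 1 (0.08 log units; within the scatter) lay within the scatter, the expected step in this assay is likewise small, a number no higher from compound 3 to compound 4 (the limit leaves the size open). Compound 4 is therefore estimated at 1080000 nM, between 500000 nM and 2500000 nM, with a good chance that the assay again reports only a limit.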

Compound 4, half-maximal cytotoxic concentration: 258000 nM
Beside the measured number, compound 4's estimate is 4.2-fold (0.62 log units) above it; the measured number lies below the stated range.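

In this assay, trifluoromethyl in place of hydrogen on an aromatic carbon gave an at least 4.1-fold lower number from compound 3 to compound 4 (0.62 log units; beyond the scatter), so the step that stayed within the scatter on the core of compound 1 did not carry over to the core of compound 4: the same change on two cores in this assay, a 1.2-fold higher number (0.08 log units; within the scatter) from compound 2 to compound 1 and an at least 4.1-fold lower number (0.62 log units; beyond the scatter) from compound 3 to compound 4, at least 5.0-fold (0.70 log units) apart, beyond the scatter of two such steps. For compound 3 the value > 1080000 nM is a limit of the assay and not a number: the limit of > 1080000 nM in this assay, at which 1 of the 4 values shown sits. The result shows that the same change can give different outcomes on these two cores, but it does not show the full size of the new step or why the cores part ways, and two pairs of compounds set no rule for the wider series.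

The compounds shown carry only hydrogen or trifluoromethyl at this place, and it remains open whether a methyl group, an amine or a carboxylic acid there would also behave differently on the two cores. As far as these compounds go, it is equally open whether the gap would persist with a longer chain at that place, or with methoxy groups in place of the two hydroxyl groups on the benzene ring.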